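Three Measured Analogues and a Fourth Awaiting Its Number

This account rests on a few compounds, and the source may have more. Where it says the series, first, only, none or still open, it means among the compounds named here.

Compound 1, `CCc1ccc(Nc2cc(NC(=O)Nc3cc(OC)cc(OC)c3)ncn2)cc1`, gives 66.2% in a functional assay on HCC827 cells (Homo sapiens) for inhibition, read by MTT assay, with a stated time of 48 h, tested at 10 uM; a lower number here means less inhibition, a higher number more inhibition at the concentration tested (going by the name of the read-out).
Compound 2, `COc1cc(NC(=O)Nc2cc(Nc3ccc(C)c(C)c3)ncn2)cc(OC)c1`, gives 45.7% in this assay.
Compound 3, `COc1cc(NC(=O)Nc2cc(Nc3ccc(Br)cc3OC)ncn2)cc(OC)c1`, gives 57.7% in this assay.

Compound 3 stands second highest of the three numbers: its gap to compound 1 is within the scatter, while compound 2 lies beyond it, as the step of a number 12 percentage points higher from compound 2 to compound 3 (beyond the scatter) shows. The unmeasured compound 4, `COc1cc(NC(=O)Nc2cc(Nc3ccc(OC)c(C)c3)ncn2)cc(OC)c1`, differs from compound 3 at a single site: 4-methoxy-3-methylphenyl in place of 4-bromo-2-methoxyphenyl on a nitrogen on an aromatic ring. Among the measured compounds shown here, every step so far has changed the same group on that nitrogen. The steps of a number 20.5 percentage points lower from compound 1 to compound 2 (beyond the scatter) and a number 8.5 percentage points lower from compound 1 to compound 3 (within the scatter) set the range seen when that group is exchanged, with the two disubstituted phenyl groups in compound 2 and compound 3 sitting at or under compound 1. Since compound 4 carries a further disubstituted phenyl there, the change a number 7.7 percentage points lower from compound 3 to compound 4 (within the scatter) is expected to be small, at most modest, and if anything downward. Compound 4 is therefore estimated at 50%, with a likely range from 35% to 65%.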

Compound 4, a percentage reported as inhibition, at one concentration (the size of the read-out at that concentration, not a potency): 48.3%
Estimate against measurement, compound 4: 1.7 percentage points above; low and high end bracket the measured number.
By their numbers in this assay, from the lowest: compounds 2, 4, 3 and 1 (each within the scatter of the next, the first and the last beyond it).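

In this assay, among the compounds shown here, methoxy in place of methyl on an aromatic carbon gives a number 2.6 percentage points higher from compound 2 to compound 4 (within the scatter) and so offers the first exchange of a single substituent on this phenyl group, one that does not separate the two compounds. Replacing the whole group on the nitrogen gives a number 9.4 percentage points lower from compound 3 to compound 4 (within the scatter) and also a number 17.9 percentage points lower from compound 1 to compound 4 (beyond the scatter) so that compound 4 joins compound 2 in lying beyond the scatter from compound 1, while compound 3 goes against this pattern by staying within it. No evidence is available here on what lies behind these numbers.

The compounds shown leave open whether a longer chain such as butyl, an amine such as morpholine or a carboxylic acid on this phenyl group would keep the number near that of compound 1. They also leave open how these exchanges would read with any other part of the shared core changed.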